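Swapping an Aromatic Ring on a Shared Core

The source may hold more compounds than are shown below. What is called first, only, known or untested is meant among the compounds shown, and "the series" means these compounds.

Among the compounds with values here, compound 2 `COc1cccc(-c2cc(-c3cc(C(C)C)c(O)cc3C)[nH]c(=O)c2C#N)c1` gives 38% in a functional assay for inhibition, tested at 60 ug/mL (a higher number here means a stronger effect of the compound at the concentration tested, a lower number a weaker effect), the upper of the two numbers measured so far, while compound 1 `Cc1cc(O)c(C(C)C)cc1-c1cc(-c2ccccc2)c(C#N)c(=O)[nH]1` in this assay gives 34%. The step of a number 4 percentage points higher from compound 1 to compound 2 (within the scatter) lies within the scatter, so the two compounds cannot be told apart. Compound 3 `Cc1cc(O)c(C(C)C)cc1-c1cc(-c2cccs2)c(C#N)c(=O)[nH]1` has not yet been tested. It differs from compound 2 in one place: thiophen-2-yl in place of 3-methoxyphenyl on an aromatic carbon. Within the data shown here, the only measured step, a number 4 percentage points higher from compound 1 to compound 2 (within the scatter), concerns a methoxy on that six-membered aromatic ring of carbon only and moved the number hardly at all; no measured pair shows what exchanging the whole ring for thiophen-2-yl does. The expectation therefore rests on two close values and is wide. The estimated step of a number 5 percentage points lower from compound 2 to compound 3 (within the scatter) for compound 3 is expected to stay small. Compound 3 is expected to give 33% in this assay, within 12% to 55%.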

Compound 3, a percentage reported as inhibition, at one concentration (the size of the read-out at that concentration, not a potency): 54.3%
The estimate for compound 3 lay 21.3 percentage points below the measured number; the measured number falls inside the stated range.
By their numbers in this assay, from the lowest: compounds 1 and 2 (each within the scatter of the next); then compound 3.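

Replacing the ring at this position, on an aromatic carbon opposite the ring nitrogen, gives in this assay a number 16.3 percentage points higher from compound 2 to compound 3 (beyond the scatter) and, against the unsubstituted phenyl, a number 20.3 percentage points higher from compound 1 to compound 3 (beyond the scatter). Compound 1 and compound 2 could not be told apart, so only compound 3 shows that the read-out responds to a change at this position, and here that change is the exchange of the whole ring rather than the addition of a methoxy. No measurement bears on why thiophen-2-yl gives the higher number.

The exchange alters both ring size and ring atoms, so these compounds cannot separate the five-membered ring from the sulfur it holds. Furan-2-yl, with oxygen in place of that sulfur, or thiophen-3-yl, attached through a different ring carbon, would test each point, while an amine or a carboxylic acid here remains an open question.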